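The source may hold more compounds than are shown below. What is called first, only, known or untested is meant among the compounds shown, and "the series" means these compounds.

Of the compounds shown here, three share one core and have been tested in an assay on isolated protein for inhibition of protein deacetylase HDAC6 (Homo sapiens); a higher number here means a weaker inhibitor, a lower number a stronger inhibitor. Compound 1 `Cc1ccc(-c2noc(-c3ccc(C(=O)C(F)(F)F)s3)n2)cc1` gives 860 nM. Compound 2 `O=C(c1ccc(-c2nc(-c3cccnc3)no2)s1)C(F)(F)F` gives 840 nM. Compound 3 `O=C(c1ccc(-c2nc(CS(=O)(=O)c3cccs3)no2)s1)C(F)(F)F` gives 520 nM. Compound 2 thus holds the second highest of the three numbers: compound 1 is nearest, and the step of a 1.0-fold lower number from compound 1 to compound 2 (0.01 log units; within the scatter) shows that swapping the group on the core barely moves the read-out; compound 3 is furthest, and its number and that of compound 2 also lie within the usual scatter of each other.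

Compound 4 `Cc1cccc(-c2noc(-c3ccc(C(=O)C(F)(F)F)s3)n2)c1` has not yet been measured. It differs from compound 2 in one place: 3-methylphenyl in place of pyridin-3-yl on an aromatic carbon. Within the data shown here, the only measured step that bears on this kind of change is a 1.0-fold lower number from compound 1 to compound 2 (0.01 log units; within the scatter), where a methyl-bearing phenyl was replaced by the pyridine ring, and the number stayed put. Compound 4 reverses that kind of exchange, putting a methylphenyl back in place of the pyridine. Since the earlier exchange at this position did nothing beyond the scatter, no change beyond the scatter is expected here either, and the expected step of a 1.0-fold higher number from compound 2 to compound 4 (0.01 log units; within the scatter) is essentially flat. Compound 4 is therefore estimated at 850 nM, with a range from 400 nM to 1800 nM.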

Compound 4, half-maximal inhibitory concentration: 680 nM
Compound 4: middle estimate off by 1.3-fold (0.10 log units), on the high side; measured number inside the range.
By their numbers in this assay, from the lowest: compounds 3, 4, 2 and 1 (each within the scatter of the next).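

Among these compounds, at this place on the shared core, on an aromatic carbon between two ring nitrogen atoms, the earlier compounds compared only one methylphenyl with pyridin-3-yl, and now a second methylphenyl can be set against each of them. In this assay the exchange of pyridin-3-yl for 3-methylphenyl gives a 1.2-fold lower number from compound 2 to compound 4 (0.09 log units; within the scatter) and so stays within the scatter even though the entering ring is carbon only and has no hydrogen-bond acceptor, while the move from 4-methylphenyl to 3-methylphenyl gives a 1.3-fold lower number from compound 1 to compound 4 (0.10 log units; within the scatter) and shows that where the methyl sits on the phenyl ring makes no readable difference either. No outside measurement is available to explain why compounds 1, 2 and 4 read alike.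

These three compounds cover only six-membered aromatic rings with either a single methyl or a ring nitrogen, so they cannot show how far this tolerance extends. As far as these compounds go, whether an amine or a carboxylic acid on that ring, or a longer chain in its place, would move the number beyond the scatter remains open.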